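Aryl change on the ring nitrogen: compound 3 to compound 4

The source may report more compounds than this note shows. Statements on the series, on what has been measured and on what is new or still open speak of the compounds shown alone.

Compound 3 `CC1(C)[C@H]2CC[C@]1(C)N(Cc1cn(-c3ccccc3F)nn1)C(=O)C2` gives 240 nM in a functional assay on A549 cells (Homo sapiens) for inhibition, read by MTT assay, with a stated time of 24 h (a lower number here means a stronger inhibitor, a higher number a weaker inhibitor), the second highest of the three numbers; compound 1 `Cc1ccc(-n2cc(CN3C(=O)C[C@@H]4CC[C@@]3(C)C4(C)C)nn2)cc1` gives 400 nM and compound 2 `CC1(C)[C@H]2CC[C@]1(C)N(Cc1cn(-c3ccccc3Cl)nn1)C(=O)C2` gives 70 nM. The step of a 3.4-fold higher number from compound 2 to compound 3 (0.54 log units; beyond the scatter) is modest, whereas a 1.7-fold lower number from compound 1 to compound 3 (0.22 log units; within the scatter) stays within the scatter. Compound 4 `Cc1cccc(-n2cc(CN3C(=O)C[C@@H]4CC[C@@]3(C)C4(C)C)nn2)c1` carries 3-methylphenyl in place of 2-fluorophenyl on an aromatic nitrogen. Going by the values given here, no measured pair covers 3-methylphenyl directly; the nearest guide is a 1.7-fold lower number from compound 1 to compound 3 (0.22 log units; within the scatter), where a methylphenyl and 2-fluorophenyl give numbers within the scatter of each other, while a 3.4-fold higher number from compound 2 to compound 3 (0.54 log units; beyond the scatter) shows that only the chloro compound separates from the rest. The expected step is therefore a 1.3-fold higher number from compound 3 to compound 4 (0.10 log units; within the scatter), not beyond the scatter. Compound 4 is estimated at 300 nM, with a range from 120 nM to 800 nM.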

Compound 4, half-maximal inhibitory concentration: 50 nM
The estimate for compound 4 lay 6.0-fold (0.78 log units) above the measured number; the measured number lies below the stated range.
By their numbers in this assay, from the lowest: compounds 4 and 2 (each within the scatter of the next); then compounds 3 and 1 (each within the scatter of the next).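

In this assay, going by these compounds alone, the aryl group on the aromatic nitrogen is sensitive to where the methyl stands: 3-methylphenyl in place of 4-methylphenyl gives an 8.0-fold lower number from compound 1 to compound 4 (0.90 log units; beyond the scatter), a separation between methylphenyl groups that the earlier compounds could not show. Replacing 2-fluorophenyl gives a 4.8-fold lower number from compound 3 to compound 4 (0.68 log units; beyond the scatter), while a 1.4-fold lower number from compound 2 to compound 4 (0.15 log units; within the scatter) stays within the scatter, so 2-chlorophenyl no longer stands alone among these aryl groups. Nothing measured here explains these differences.

Still open, as far as these compounds go, is whether 2-methylphenyl or 3-chlorophenyl would follow the same trend. From the compounds shown here alone, how an amine or a carboxylic acid on this phenyl ring would read also remains unknown.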